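Difluoromethoxy on the fused ring of compound 1

This account rests on a few compounds, and the source may have more. Where it says the series, first, only, none or still open, it means among the compounds named here.

Measured so far:
- Compound 1, `CCOC(=O)c1c(-c2ccccc2)nn(-c2ccccc2)c1Cn1c(S)nc2ccccc21`: 40 ug/mL
- Compound 2, `CCOC(=O)c1c(-c2ccccc2)nn(-c2ccccc2)c1Cn1cnc2ccccc21`: 35 ug/mL

The two compounds share one core and differ only in hydrogen in place of sulfanyl on an aromatic carbon. In an assay for inhibition of Alpha amylase (Homo sapiens), with a stated time of 30 min (a higher number here means a weaker inhibitor, a lower number a stronger inhibitor), compound 1 gives 40 ug/mL and compound 2 gives 35 ug/mL; the step of a 1.1-fold lower number from compound 1 to compound 2 (0.06 log units; within the scatter) is within the scatter, so on the numbers shown compound 1 is not separated from compound 2.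

Compound 3, `CCOC(=O)c1c(-c2ccccc2)nn(-c2ccccc2)c1Cn1c(S)nc2ccc(OC(F)F)cc21`, is not yet measured. It keeps the sulfanyl of compound 1 and differs from it by difluoromethoxy in place of hydrogen on an aromatic carbon, on the six-membered carbon ring of the fused system, meta and para to the fused ring.

For the measured compounds named here, no measured step bears directly on this change: the only step known, from compound 1 to compound 2, alters a different position and is itself within the scatter. There is therefore no basis in the series for a step beyond the scatter in this assay in either direction.

For compound 3 the expected value in this assay is 35 ug/mL, within 15 ug/mL to 90 ug/mL, which as a step from compound 1 means an estimated 1.1-fold lower number from compound 1 to compound 3 (0.06 log units; within the scatter).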

Compound 3, half-maximal inhibitory concentration: 10 ug/mL
The estimate for compound 3 lay 3.5-fold (0.54 log units) above the measured number, and the stated range ends above it.
By their numbers in this assay, from the lowest: compound 3; then compounds 2 and 1 (each within the scatter of the next).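

In this assay, for the compounds shown here, the six-membered aromatic ring of the fused system is a place where a substitution registers: difluoromethoxy in place of hydrogen on an aromatic carbon gives a 4.0-fold lower number from compound 1 to compound 3 (0.60 log units; beyond the scatter), whereas the only earlier step, a 1.1-fold lower number from compound 1 to compound 2 (0.06 log units; within the scatter), did not separate its two compounds. Going by these compounds alone, this modest step is the first change to lie beyond the scatter, and it occurs with the sulfanyl kept in place. Nothing at hand accounts for the shift, so it stands as an observation on one group at one position.

Open, going by these compounds, is whether the step is particular to difluoromethoxy or would also appear with methoxy, a chlorine atom, an amine or a carboxylic acid on the same aromatic carbon. Also open, on these data alone, is whether difluoromethoxy gives a step of similar size on the core of compound 2, which lacks the sulfanyl, and whether the same group would give a comparable step on another carbon of that ring.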